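This account rests on a few compounds, and the source may have more. Where it says the series, first, only, none or still open, it means among the compounds named here.

For the measured compounds named here, in a functional assay on HL-60 cells (Homo sapiens) for antiproliferative activity, read by MTT assay, with a stated time of 72 h (a lower number here means a stronger inhibitor, a higher number a weaker inhibitor), compound 1 `NC1=NC2(CCSCC2)N(OCCCOc2ccc(Br)cc2)C(N)=N1` gives 350 nM and compound 2 `NC1=NC2(CCSCC2)N(OCCCOc2ccccc2Br)C(N)=N1` gives 180 nM as the only two measured values, which places compound 2 within the scatter of compound 1. Compound 3 `NC1=NC2(CCSCC2)N(OCCCOc2cccc(Br)c2)C(N)=N1` is the next case, with 3-bromophenyl in place of 2-bromophenyl on an oxygen on a saturated carbon and the shared core unchanged. Going by the values given here, one measured step bears on this, the exchange of 4-bromophenyl for 2-bromophenyl, which gives a 1.9-fold lower number from compound 1 to compound 2 (0.29 log units; within the scatter) and is the same kind of swap of one bromophenyl for another. Among the compounds with values here, no measured compound yet carries 3-bromophenyl, so the evidence is thin. In this assay no step beyond the scatter is expected, in either direction. The estimated change is a 1.4-fold higher number from compound 2 to compound 3 (0.14 log units; within the scatter) as a working figure. Compound 3 is estimated at 250 nM with an expected range of 100 nM to 600 nM for now.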

Compound 3, half-maximal inhibitory concentration: 200 nM
The estimate for compound 3 lay 1.3-fold (0.10 log units) above the measured number; the measured number falls inside the stated range.
By their numbers in this assay, from the lowest: compounds 2, 3 and 1 (each within the scatter of the next).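

Compound 3 completes the set of 2-bromophenyl, 3-bromophenyl and 4-bromophenyl on an oxygen on a saturated carbon, and in this assay its two new steps stay within the scatter (a 1.1-fold higher number from compound 2 to compound 3 (0.05 log units; within the scatter); a 1.8-fold lower number from compound 1 to compound 3 (0.24 log units; within the scatter)). With the earlier step, every pair among these three compounds now lies within the scatter, so the bromine's ring location does not separate them in this assay. Nothing on hand offers an explanation for these values.

On these data alone, how far this tolerance extends remains open, since the set does not show how unsubstituted phenyl, 3-chlorophenyl, 3-methoxyphenyl or pyridyl would read at this place. As far as these compounds go, the effect of a longer chain, or of an amine in place of the bromophenyl, also remains open.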